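A Larger Substituent on the Chain of Compound 1

The source may hold more compounds than are shown below. What is called first, only, known or untested is meant among the compounds shown, and "the series" means these compounds.

Of the compounds shown here, three have been measured in an assay for displacement of a labelled ligand from protein arginine N-methyltransferase 1 (Homo sapiens), read by scintillation proximity assay, with stated times of 5 min and 8 min, tested at 10 uM; on this read-out lower numbers stand for a weaker effect and higher numbers for a stronger effect at the one concentration tested. Compound 1, with structure `CCCCN1/C(=C/C(C)=C/c2sc3ccccc3[n+]2CCCC)Sc2ccccc21`, gives 77% in this assay. Compound 2, with structure `CCCCN1/C(=C/C=C/C2=[N+](CCCC)c3ccc(Br)cc3C2(C)C)C(C)(C)c2cc(Br)ccc21`, gives 48%, and compound 3, with structure `CN1/C(=C/C=C/C2=[N+](CCC[N+](C)(C)C)c3ccccc3C2(C)C)C(C)(C)c2ccccc21`, gives 2%. Compound 1 thus shows the highest number of the three: the value of compound 2 is lower by an amount beyond the scatter, and the value of compound 3 is lower by a far larger amount, also beyond the scatter. Among the measured compounds shown here, no single-point step between these measured compounds has been characterised, so only the values themselves can be compared.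

Compound 4, with structure `CCCCN1/C(=C/C(/C=C/c2ccccc2)=C/c2sc3ccccc3[n+]2CCCC)Sc2ccccc21`, has not yet been tested in this assay. It differs from compound 1 in one place: 2-phenylethenyl in place of methyl on a double-bonded chain carbon bound to two double-bonded chain carbons. The group that enters is much larger than the methyl it replaces, and the only reference point is the value of compound 1.

Compound 4 is expected to give 65% in this assay, within a range from 30% to 90%. This estimate means a step of a number 12 percentage points lower from compound 1 to compound 4 (beyond the scatter), which is expected to be a modest decrease, possibly no larger than the usual scatter.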

Compound 4, a percentage reported as inhibition, at one concentration (the size of the read-out at that concentration, not a potency): 48%
Compound 4: the middle estimate sits 17 percentage points above what was measured, within the range that was stated.
By their numbers in this assay, from the lowest: compound 3; then compounds 2 and 4 (each within the scatter of the next); then compound 1.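

Among the compounds shown here, the change of methyl to 2-phenylethenyl on a double-bonded chain carbon bound to two double-bonded chain carbons gives, in this assay, a step of a number 29 percentage points lower from compound 1 to compound 4 (beyond the scatter) and is the first single-place comparison in this set. It shows that this chain position has a bearing on the read-out, since a change made there alone moves the number by more than the scatter. It also shows that the read-out is lowered but not abolished with the larger group in place, as compound 4 still gives 48% at the one concentration tested, and no measurement available here explains this decrease.

With only methyl and 2-phenylethenyl compared at this position, the compounds shown leave open whether the decrease goes with the added phenyl ring, the added chain double bond, or simply the greater number of atoms. An ethyl, a phenyl or a 2-phenylethyl group at the same carbon would help to separate these, while an aminomethyl or carboxylic acid group would show how the read-out responds to a group bearing nitrogen or oxygen there.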